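The compounds below may be only part of what the source reports. "The series", "measured", "known", "first", "only" and "open" are said of these compounds alone.

In a functional assay on HT-1080 cells (Homo sapiens) for antiproliferative activity, read by MTT assay, with a stated time of 72 h (on this read-out lower numbers stand for stronger inhibition and higher numbers for weaker inhibition), compound 1 `COc1ccc(-c2cc(C(=O)O)sc2-c2cc(OC)c(OC)c(OC)c2)cc1` gives 5810 nM and compound 2 `COc1ccc(-c2ccsc2-c2cc(OC)c(OC)c(OC)c2)cc1` gives 3620 nM, so the two values lie within the scatter of each other. Compound 3 `COc1ccc(-c2ccsc2-c2cc(OC)c(OC)c(OC)c2)cc1O` differs from compound 2 by hydroxy in place of hydrogen on an aromatic carbon, ortho to a methoxy group and meta to a large group: hydroxy in place of hydrogen on an aromatic carbon. For the measured compounds named here, only one measured step is available, a 1.6-fold lower number from compound 1 to compound 2 (0.21 log units; within the scatter), which removes carboxy from a different place in the molecule. Going by the values given here, it therefore says little about a change on this six-membered ring, and no measured compound carries hydroxy. A move towards a lower number in this assay is expected, but its size is poorly constrained by these data. The estimated change is a 4.5-fold lower number from compound 2 to compound 3 (0.66 log units; beyond the scatter). Compound 3 is expected to give about 800 nM, within an estimated range of 60 nM to 5000 nM.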

Compound 3, half-maximal inhibitory concentration: 2120 nM
The estimate for compound 3 lay 2.7-fold (0.42 log units) below the measured number; low and high end bracket the measured number.
By their numbers in this assay, from the lowest: compounds 3, 2 and 1 (each within the scatter of the next, the first and the last beyond it).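

In this assay, for the compounds shown here, hydroxy in place of hydrogen on an aromatic carbon, ortho to a methoxy group and meta to a large group, gives a 1.7-fold lower number from compound 2 to compound 3 (0.23 log units; within the scatter), the first reading of a change on this six-membered ring. It shows that this position takes a hydroxy group without a difference that stands clear of the usual scatter, so compound 2 and compound 3 cannot be told apart on this read-out. No available evidence bears on the size of this step.

From the compounds shown here alone, whether another group at this position, such as an amine, a fluorine atom or a longer alkoxy chain, would move the value beyond the scatter remains open. Also open, going by these compounds, is whether the hydroxy step would read the same on the core of compound 1, which carries carboxy.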